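Opening a Ring on the Amide Side of a Weak Binder

A few compounds are considered here, and "the series" means these few. Any claim that something is new, unique, unknown or untested is made for them only; others in the source may bear on it.

Three compounds that share one core differ only in the group on the carbonyl carbon of the amide. Compound 1 `CC(C)N[C@H](C)C(=O)N1CCN(CCCOc2ccc(C(=O)C3CC3)cc2)CC1` gives 50100 nM in an assay for binding affinity to histamine H2 receptor (Homo sapiens); on this read-out higher numbers stand for weaker inhibition and lower numbers for stronger inhibition. Compound 2 `CC(C)(C)OC[C@@H](N)C(=O)N1CCN(CCCOc2ccc(C(=O)C3CC3)cc2)CC1` gives 45700 nM, and compound 3 `O=C(c1ccc(OCCCN2CCN(C(=O)[C@H]3CCCN3)CC2)cc1)C1CC1` gives 53700 nM. Compound 3 has the highest of the three numbers, but the steps of a 1.1-fold higher number from compound 1 to compound 3 (0.03 log units; within the scatter) and a 1.2-fold higher number from compound 2 to compound 3 (0.07 log units; within the scatter) are both within the scatter, as is a 1.1-fold lower number from compound 1 to compound 2 (0.04 log units; within the scatter), so the three compounds cannot be told apart on this read-out.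

Compound 4 `NCCC(=O)N1CCN(CCCOc2ccc(C(=O)C3CC3)cc2)CC1` takes the change (2-aminoethyl in place of pyrrolidin-2-yl on a carbonyl carbon). Each of the three measured steps bears on it, since each exchanges the group on the same carbonyl carbon, and none of them moved the number beyond the scatter. Opening the five-membered ring into a 2-aminoethyl chain is a change of the same kind, and the numbers so far give no sign that this position drives the result. The step from compound 3 to compound 4 is therefore expected to stay within the scatter, with a step of a 1.1-fold lower number from compound 3 to compound 4 (0.03 log units; within the scatter). For compound 4 the estimate is 50000 nM, with a range from 20000 nM to 130000 nM.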

Compound 4, inhibition constant: 100000 nM
Beside the measured number, compound 4's estimate is 2.0-fold (0.30 log units) below it, within the range that was stated.
By their numbers in this assay, from the lowest: compounds 2, 1, 3 and 4 (each within the scatter of the next, the first and the last beyond it).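

In this assay this position had not yet produced a step beyond the scatter, and compound 4 provides the first, though only a modest one: a 2.2-fold higher number from compound 2 to compound 4 (0.34 log units; beyond the scatter). The other two routes to the same group stay inside the scatter, with a 1.9-fold higher number from compound 3 to compound 4 (0.27 log units; within the scatter) and a 2.0-fold higher number from compound 1 to compound 4 (0.30 log units; within the scatter), so the 2-aminoethyl group is separated from only one of the three earlier groups, the 1-amino-2-(tert-butoxy)ethyl group, and opening the pyrrolidin-2-yl ring removes the ring and the defined stereocentre without a step that can be told from scatter, while the counts of hydrogen-bond donors and acceptors stay the same. Nothing shown gives a reason why the step from the 1-amino-2-(tert-butoxy)ethyl group alone passes the scatter.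

The compounds shown leave open whether a longer chain with its amine at the end, such as 3-aminopropyl, would carry the number further in the same direction. They also leave open whether a dimethylamino group in place of the primary amine of the 2-aminoethyl chain, or a carboxylic acid in its place, would separate clearly from all of these compounds.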